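This account rests on a few compounds, and the source may have more. Where it says the series, first, only, none or still open, it means among the compounds named here.

Three compounds have been measured in a functional assay on MDA-MB-231 cells (Homo sapiens) for cytotoxicity, read by MTT assay, with a stated time of 24 h; a lower number here means a stronger inhibitor, a higher number a weaker inhibitor:

Compound 1, `CCCCCCCCCCCCCCCCCC(=O)Nc1nnc(S[C@@H]2O[C@H](CO)[C@H](O)[C@H](O)[C@H]2O)s1`, gives 67100 nM.
Compound 2, `CCCCCCCCCC(=O)Nc1nnc(S[C@@H]2O[C@H](CO)[C@H](O)[C@H](O)[C@H]2O)s1`, gives 53100 nM.
Compound 3, `CCCCCCCCCCCCCCCCCC(=O)Nc1nnc(S[C@@H]2O[C@H](COC(C)=O)[C@H](OC(C)=O)[C@H](OC(C)=O)[C@H]2OC(C)=O)s1`, gives 23600 nM.

Compound 1 and compound 2 share a core and differ in one place only: hydrogen in place of octyl on a saturated chain carbon, nine bonds along the chain from a carbonyl carbon. This change gave a 1.3-fold lower number from compound 1 to compound 2 (0.10 log units; within the scatter), so the two compounds cannot be told apart on this read-out. Compound 3 carries a different core, and the difference between the core of compound 3 and the core of compound 1 is not broken down here. On its own numbers, compound 3 stands lowest of the three, and its distance to both compound 1 and compound 2 is beyond the usual scatter.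

Compound 4, `CCCCCCCCCC(=O)Nc1nnc(S[C@@H]2O[C@H](COC(C)=O)[C@H](OC(C)=O)[C@H](OC(C)=O)[C@H]2OC(C)=O)s1`, has not yet been measured. It differs from compound 3 by hydrogen in place of octyl on a saturated chain carbon, nine bonds along the chain from a carbonyl carbon. The place is described in the same words as for the step from compound 1 to compound 2, so this is the same change made once more, now on the core of compound 3. Since the earlier occurrence, from compound 1 to compound 2, gave a 1.3-fold lower number from compound 1 to compound 2 (0.10 log units; within the scatter), a step of similar small size is expected here, namely a 1.2-fold lower number from compound 3 to compound 4 (0.07 log units; within the scatter). On that basis compound 4 is estimated to give 20000 nM in this assay, with a plausible range from 8000 nM to 50000 nM.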

Compound 4, half-maximal inhibitory concentration: 19200 nM
For compound 4 the middle estimate is 1.0-fold (0.02 log units) above the measured one, within the range that was stated.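

In this assay, hydrogen in place of octyl on a saturated chain carbon, nine bonds along the chain from a carbonyl carbon, gave a step on the core of compound 3 (a 1.2-fold lower number from compound 3 to compound 4 (0.09 log units; within the scatter)) that cannot be told apart from repeat scatter. Set beside the earlier occurrence of the same change on the core of compound 1, the two steps agree, so in this series the change carries from one core to the other without a detectable difference: the same change on two cores in this assay, a 1.3-fold lower number (0.10 log units; within the scatter) from compound 1 to compound 2 and a 1.2-fold lower number (0.09 log units; within the scatter) from compound 3 to compound 4, 1.0-fold (0.01 log units) apart, within the scatter of two such steps. For the compounds shown here, this rests on only two pairs of compounds, both with steps within the scatter, so it shows that the change is equally without a readable result on these two cores, not that it would stay so on any other core, and it gives no reason for that agreement.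

The compounds shown leave open whether the same holds for a chain much shorter than that of compound 2, such as a propyl group, for a chain longer than that of compound 1, or for a chain ending in an amine or a carboxylic acid. They also leave open whether this agreement would persist on a third core or in cells other than those of this read-out.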